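A few compounds are considered here, and "the series" means these few. Any claim that something is new, unique, unknown or untested is made for them only; others in the source may bear on it.

The compounds share one core, a saturated polycyclic amine, and differ only in the group carried on the chain bound to the amine nitrogen. Compound 1 `c1cncc(CN[C@H]2C3C4CC5C6C4CC3C6C52)c1` carries a pyridin-3-yl group on that chain carbon. In an assay on isolated protein for inhibition of Alpha-2C adrenergic receptor (Homo sapiens) (a lower number here means a stronger inhibitor, a higher number a weaker inhibitor), compound 1 is recorded as "not determined" (no result reported), so it cannot be placed on the scale at all. Compound 2 `Fc1cccc(CCCN[C@H]2C3C4CC5C6C4CC3C6C52)c1`, with a longer chain and a fluorinated aryl group, is in the same position: in this assay compound 2 is likewise recorded as "not determined" (no result reported). Among the compounds with values here, the only member with a measured value is compound 3 `COc1cc(CN[C@H]2C3C4CC5C6C4CC3C6C52)cc(OC)c1OC`, which in this assay gives 2280 nM, a weak inhibition on the scale of this read-out.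

Compound 4 `C1CCC(CN[C@H]2C3C4CC5C6C4CC3C6C52)CC1` is derived from compound 1 by the change (cyclohexyl in place of pyridin-3-yl on a saturated chain carbon bound to an amine nitrogen). Within the data shown here, since compound 1 has no number, the step from compound 1 to compound 4 cannot be given a size or a direction from the data; the only anchor is compound 3, whose value 2280 nM sets the single known level for this core. On that basis compound 4 is expected to fall in the same weak region, with an estimated inhibition constant of 1500 nM, in a range from 300 nM to 8000 nM.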

Compound 4, inhibition constant: 1510 nM
Beside the measured number, compound 4's estimate is 1.0-fold (0.00 log units) below it, and the stated range covers the measured number.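

Within the data shown here, no step from compound 1 to compound 4 can be read in this assay, as compound 1 has no single number there. Nothing further is available that bears on this result. The compounds shown leave open whether cyclohexyl in place of pyridin-3-yl on the shared core changes the inhibition constant at all, and in which direction.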